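Adding methylsulfonyl to compound 2

The source may hold more compounds than are shown below. What is called first, only, known or untested is meant among the compounds shown, and "the series" means these compounds.

Measured so far in a functional assay on SW-620 cells (Homo sapiens) for cytotoxicity (a lower number here means a stronger inhibitor, a higher number a weaker inhibitor), are two compounds
- compound 1 `COc1ccc2nc(NC(=O)CCCCC(=O)NO)sc2c1` gives 9.07 ug/mL as its value
- compound 2 `O=C(CCCCCCC(=O)Nc1nc2ccccc2s1)NO` gives 4.01 ug/mL as its value

Compound 2 holds the lower of the two numbers in this assay and stands apart from compound 1 by more than the scatter. Compound 3 `CS(=O)(=O)c1ccc2nc(NC(=O)CCCCCCC(=O)NO)sc2c1` differs from compound 2 in one place (methylsulfonyl in place of hydrogen on an aromatic carbon), with methylsulfonyl in place of hydrogen on an aromatic carbon. Within the data shown here, no two measured compounds differ in one place only, so the data offer no measured guide to the size of this step. No step beyond the scatter is therefore expected, in either direction. The estimated step of a 1.1-fold lower number from compound 2 to compound 3 (0.06 log units; within the scatter) stays within the scatter, although the uncertainty is wide. Compound 3 is expected at 3.5 ug/mL in this assay, with an estimated range from 1.2 ug/mL to 10 ug/mL for this measurement.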

Compound 3, half-maximal inhibitory concentration: 5.42 ug/mL
Estimate against measurement, compound 3: 1.5-fold (0.19 log units) below, and the stated range covers the measured number.
By their numbers in this assay, from the lowest: compounds 2, 3 and 1 (each within the scatter of the next, the first and the last beyond it).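

In this assay, methylsulfonyl in place of hydrogen on an aromatic carbon gives a 1.4-fold higher number from compound 2 to compound 3 (0.13 log units; within the scatter), so this position of the shared core accepts a group of 4 heavy atoms with no step beyond the scatter. Among these compounds, compound 1 and compound 2 differ in more than one place and gave no such single-change reading, which makes this the only direct reading at this position so far. Nothing measured here bears on why the step stays within the scatter.

A single group cannot show how an amine or a carboxylic acid on the same aromatic carbon would read in this assay, or whether the other aromatic carbons of the ring would respond alike. Also open, on these data alone, is whether methylsulfonyl would give a similar step on a longer chain than that of compound 3.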